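Swapping a fluorophenyl arm for an ethynyl on pyridine cores

This account rests on a few compounds, and the source may have more. Where it says the series, first, only, none or still open, it means among the compounds named here.

Compound 1 `Cc1nc(C#Cc2cncc(-c3ccc(F)cc3)c2)cs1` and compound 2 `C#Cc1cncc(C#Cc2csc(C)n2)c1` share one core and differ in a single place: ethynyl in place of 4-fluorophenyl on an aromatic carbon. In a functional assay on CHO cells for agonist activity at metabotropic glutamate receptor 5 (Homo sapiens), read by inositol phosphate accumulation (a lower number here means a stronger inhibitor, a higher number a weaker inhibitor), compound 1 gives 162 nM, while compound 2 gives 19.2 nM, so the change made an 8.4-fold lower number from compound 1 to compound 2 (0.93 log units; beyond the scatter).

Compound 3 `Cc1nc(C#Cc2ccc(-c3ccc(F)cc3)nc2)cs1` is built from the same atoms as compound 1, joined differently; the difference between the two cores is not broken down here. In this assay, among the measured compounds shown here, compound 3 gives 10.2 nM, a number within the usual scatter of the one for compound 2 and far beyond the scatter from the one for compound 1.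

Compound 4 `C#Cc1ccc(C#Cc2csc(C)n2)cn1` has not yet been measured. It stands to compound 3 as compound 2 stands to compound 1: ethynyl in place of 4-fluorophenyl on an aromatic carbon. This is the same kind of change, not the same change. In compound 1 the group sits two atoms from the ring nitrogen, meta to a group of 8 heavy atoms, whereas in compound 3 it sits next to the ring nitrogen, para to a group of 8 heavy atoms.

The step from compound 3 to compound 4 is expected to be smaller than the earlier one, roughly a 2.0-fold lower number from compound 3 to compound 4 (0.31 log units; beyond the scatter). For the measured compounds named here, this expectation rests on compound 3 already standing at 10.2 nM, on only one measured example of the change, and on the different surroundings of the place. For compound 4 the estimate in this assay is 5 nM, with a likely range from 1.2 nM to 25 nM.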

Compound 4, half-maximal inhibitory concentration: 2950 nM
Compound 4: the middle estimate sits 590-fold (2.77 log units) below what was measured; measured number outside the range, above it.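

In this assay, the swap of 4-fluorophenyl for ethynyl does not carry over from one core to the other: on the core of compound 3 it gives a 290-fold higher number from compound 3 to compound 4 (2.46 log units; beyond the scatter), the opposite direction from the step on the core of compound 1. Set side by side, the two steps differ far more than repeated measurements would explain: the same change on two cores in this assay, an 8.4-fold lower number (0.93 log units; beyond the scatter) from compound 1 to compound 2 and a 290-fold higher number (2.46 log units; beyond the scatter) from compound 3 to compound 4, 2400-fold (3.39 log units) apart, beyond the scatter of two such steps This shows that, in this series, the result of the swap on one core says little about its result on the other, even for its direction, but with only two pairs it does not show why the cores respond differently or how the swap would behave on any further core.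

The compounds shown leave open whether the sharp weakening on the core of compound 3 is specific to ethynyl or would follow any replacement of 4-fluorophenyl at the place next to the ring nitrogen. A small group such as methyl, a nitrile or an amine at that place, or a phenyl without its fluorine, could show which replacements keep the number close to the 10.2 nM of compound 3.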